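Replacing chloro by methyl on an inactive pyrazole pair

The compounds below may be only part of what the source reports. "The series", "measured", "known", "first", "only" and "open" are said of these compounds alone.

Compound 1, `CC(C)(C)NCc1c(C(=O)O)nn(-c2ccccc2)c1-c1ccc(Cl)cc1`: in a functional assay on 786-0 cells (Homo sapiens) for inhibition, read by sulforhodamine B assay, with a stated time of 48 h (a lower number here means a stronger inhibitor of growth, a higher number a weaker inhibitor of growth), compound 1 gives only the assay limit > 652000 nM.
Compound 2, `CC(C)(C)NCc1c(C(=O)O)nn(-c2ccc(Cl)cc2)c1-c1ccc(Cl)cc1`: in this assay compound 2 gives only the assay limit > 599000 nM.

Compound 2 therefore stands at a limit, not at a measured number, and the step that the two limits leave unreadable from compound 1 to compound 2 cannot be read because both of its values are limits. Compound 3, `Cc1ccc(-c2c(CNC(C)(C)C)c(C(=O)O)nn2-c2ccc(Cl)cc2)cc1`, differs from compound 2 by methyl in place of chloro on an aromatic carbon. Within the data shown here, no measured step shows how this change acts, so no direction can be expected beyond the scatter. Compound 3 is expected to stay at or near the limit, at an estimated 600000 nM (range 150000 nM to 2400000 nM), which would mean a step that the limit leaves unreadable from compound 2 to compound 3.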

Compound 3, concentration for 50% growth inhibition: > 629000 nM
Compound 3 gave a limit, no number; the forecaster's own chance of this, stated with the estimate: 80%; middle value at least 1.0-fold (0.02 log units) away from the limit.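

Compound 3 gives only the limit > 629000 nM, and compound 2 also stands at a limit, so the step between them cannot be read. Whether 4-methylphenyl in place of 4-chlorophenyl alters growth inhibition at all stays open among the compounds shown.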